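A few compounds are considered here, and "the series" means these few. Any claim that something is new, unique, unknown or untested is made for them only; others in the source may bear on it.

Working notes on the series

Two members have been measured in a functional assay on COLO 205 cells (Homo sapiens) for inhibition, read by sulforhodamine B assay, with a stated time of 48 h, tested at 10 uM; a lower number here means a stronger effect, a higher number a weaker effect of the compound at the concentration tested. Compound 1 `COc1cc2cc(Oc3ccc(NC(=O)Nc4ccccc4)cc3)c(C)nc2cc1OC` gives 85.7% in this assay. Compound 2 `COc1cc2cc(Oc3ccc(NC(=O)Nc4ccc(C(F)(F)F)cc4)cc3)c(C)nc2cc1OC` gives 40.4% in this assay. Going by the values given here, the only step so far, a number 45.3 percentage points lower from compound 1 to compound 2 (beyond the scatter), is a large one and lies beyond the scatter. Compound 2 therefore stands lowest of the two numbers, with compound 1 the nearest and well above it.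

Compound 3 `COc1cc2cc(Oc3ccc(NC(=O)Nc4ccc(Cl)c(Cl)c4)cc3)c(C)nc2cc1OC` has not been measured. The change from compound 2 is 3,4-dichlorophenyl in place of 4-(trifluoromethyl)phenyl on an amide-type nitrogen.

Among the compounds with values here, no measured step bears directly on this change: the one step available, a number 45.3 percentage points lower from compound 1 to compound 2 (beyond the scatter), concerns the introduction of trifluoromethyl onto an unsubstituted ring, and it gives no reading for the exchange of one substituted ring for another. What it does show is that the substituted ring on the amide-type nitrogen sits far below the unsubstituted one. A substituted ring is kept in compound 3, so no step beyond the scatter is expected from compound 2, with the direction open.

Estimated for compound 3 in this assay: 38%, with a range from 15% to 62%, which means an expected step of a number 2.4 percentage points lower from compound 2 to compound 3 (within the scatter).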

Compound 3, a percentage reported as activity, at one concentration (the size of the read-out at that concentration, not a potency): 4.03%
Beside the measured number, compound 3's estimate is 34 percentage points above it; the measured number lies below the stated range.
By their numbers in this assay, from the lowest: compound 3; then compound 2; then compound 1.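

In this assay, the ring on the amide-type nitrogen turns out not to be a place where one substituted ring serves as well as another: 3,4-dichlorophenyl in place of 4-(trifluoromethyl)phenyl gives a number 36.4 percentage points lower from compound 2 to compound 3 (beyond the scatter), so the identity of the substituents matters here and not only their presence. Set against the unsubstituted phenyl of the parent, the same 3,4-dichlorophenyl group gives a number 81.7 percentage points lower from compound 1 to compound 3 (beyond the scatter), which leaves compound 3 lowest of the three and close to the full effect that this read-out can show at the concentration tested. Nothing in hand explains why these two substituted rings differ so widely.

On these data alone, compound 3 carries two chlorines at once, so the share of each stays open, and a ring with a single chlorine, or one bearing a nitrile or a methoxy group, would show whether the gain follows the halogen or the substitution pattern. As far as these compounds go, these figures are also read-outs at one concentration and not potencies, so the size of the separation between compound 2 and compound 3 on a potency scale remains unknown.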